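The compounds below may be only part of what the source reports. "The series", "measured", "known", "first", "only" and "open" are said of these compounds alone.

Compound 1 `COc1ccc(CNc2ncnc3c2ncn3[C@@H]2O[C@H](CO)[C@@H](O)[C@H]2O)c(OC)c1` carries a 2,4-dimethoxyphenyl on the saturated chain carbon bound to the nitrogen of the shared core, and compound 2 `OC[C@H]1O[C@@H](n2cnc3c(NCc4cc(O)cc(O)c4)ncnc32)[C@H](O)[C@@H]1O` carries a 3,5-dihydroxyphenyl at the same place. In a functional assay on MCF cells (Homo sapiens) for antiproliferative activity, with a stated time of 72 h (on this read-out higher numbers stand for weaker inhibition and lower numbers for stronger inhibition), compound 1 gives only a limit, > 166000 nM. In this assay compound 2 likewise gives only a limit, > 166000 nM. Among the measured compounds shown here, the single measured step, a step that the two limits leave unreadable from compound 1 to compound 2, is therefore not readable, because both values sit at the limit of > 166000 nM in this assay, at which 2 of the 2 values shown sit. Compound 3 `OC[C@H]1O[C@@H](n2cnc3c(NCc4ccc(C(F)(F)F)cc4)ncnc32)[C@H](O)[C@@H]1O` is the next change: 4-(trifluoromethyl)phenyl in place of 3,5-dihydroxyphenyl on a saturated chain carbon bound to a nitrogen on an aromatic ring. For the measured compounds named here, no measured step bears on this change in a readable way; all that is known is that neither aryl group so far gave a number within the range of this assay. Compound 3 is therefore expected at the same limit, estimated as 166000 nM with a range of 50000 nM to 500000 nM. The expected step for compound 3 is a number no higher from compound 2 to compound 3 (the limit leaves the size open), with a strong chance that only a limit is again reported.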

Compound 3, half-maximal inhibitory concentration: > 166000 nM
Compound 3: no number, only a limit; the forecaster's own chance of this, stated with the estimate: 80%; the middle value sits exactly at the limit.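

In this assay compound 3 gives > 166000 nM as a limit only. Among the compounds shown here, no step among compound 1, compound 2 and compound 3 can be read: the limit of > 166000 nM in this assay, at which 3 of the 3 values shown sit. On these data alone, whether any aryl group at this place gives a number within the range of this assay remains open.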